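A few compounds are considered here, and "the series" means these few. Any claim that something is new, unique, unknown or untested is made for them only; others in the source may bear on it.

Three compounds have so far been measured in a functional assay on U-937 cells (Homo sapiens) for antiproliferative activity, with a stated time of 48 h; on this read-out lower numbers stand for an effect already at smaller amounts and higher numbers for an effect only at larger amounts of compound:

compound 1, `O=C(CCCCCCC(=O)Nc1cccc(C(F)(F)F)c1)NO`, 1200 nM
compound 2, `O=C(CCCCCCC(=O)Nc1ccc(C(F)(F)F)cc1)NO`, 450 nM
compound 3, `O=C(CCCCCCC(=O)Nc1ccc(Cl)cc1)NO`, 550 nM

All three carry the same long chain ending in a hydroxamic acid, joined to an aromatic ring through an amide. Compound 2 and compound 3 share one core and differ in a single place: chloro in place of trifluoromethyl on an aromatic carbon. That change gave a 1.2-fold higher number from compound 2 to compound 3 (0.09 log units; within the scatter), so the two numbers cannot be told apart on this read-out. Compound 1 is built from the same atoms as compound 2, joined differently; the difference between the two cores is not broken down here. Compound 1 gives the highest number of the three, and its gaps to compound 3 and to compound 2 both lie beyond the usual scatter.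

Compound 4, `O=C(CCCCCCC(=O)Nc1cccc(Cl)c1)NO`, has not yet been measured in this assay. It comes from compound 1 by the same kind of change that turned compound 2 into compound 3: chloro in place of trifluoromethyl on an aromatic carbon. The surroundings are not identical, since in the measured pair the changed group sits para to a large group, whereas here it sits meta to a large group.

From compound 1 to compound 4 a step of a 1.2-fold higher number from compound 1 to compound 4 (0.07 log units; within the scatter) is expected, resting on the small step of a 1.2-fold higher number from compound 2 to compound 3 (0.09 log units; within the scatter) seen for the measured pair. The estimate for compound 4 in this assay is 1400 nM, with a likely range from 600 nM to 3500 nM.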

Compound 4, half-maximal effective concentration: 350 nM
Compound 4: middle estimate off by 4.0-fold (0.60 log units), on the high side; the measured number lies below the stated range.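

In this assay, putting chloro in place of trifluoromethyl on the core of compound 1 gave a 3.4-fold lower number from compound 1 to compound 4 (0.54 log units; beyond the scatter), so the change did not behave here as it had on the other core. A step measured on one core therefore could not be carried over to the other in this series, as the two steps side by side show: the same change on two cores in this assay, a 1.2-fold higher number (0.09 log units; within the scatter) from compound 2 to compound 3 and a 3.4-fold lower number (0.54 log units; beyond the scatter) from compound 1 to compound 4, 4.2-fold (0.62 log units) apart, beyond the scatter of two such steps. For the compounds shown here, with only two pairs, this does not show why the steps differ, whether the place of the group on the ring (meta to a large group in compound 4) is what matters, or how the change would behave on any further core.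

The compounds shown leave open how a fluoro, a methoxy or a nitrile at the same places on the ring would compare on the two cores, and whether the gap between the two steps would persist with a shorter or longer chain. They also leave open whether that gap would remain with a carboxylic acid at the end of the chain in place of the hydroxamic acid.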